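This account rests on a few compounds, and the source may have more. Where it says the series, first, only, none or still open, it means among the compounds named here.

Measured compounds:
Compound 1 `COc1ccc(CNc2cc(OC)c(OC)c(OC)c2)cc1Br` — 48100 nM
Compound 2 `COc1ccc(CN(C(=O)CCCl)c2cc(OC)c(OC)c(OC)c2)cc1O` — 150 nM
Compound 3 `COc1ccc(CNc2cc(OC)c(OC)c(OC)c2)cc1[N+](=O)[O-]` — 18200 nM

In a functional assay on HCT-116 cells (Homo sapiens) for inhibition, read by MTT assay, with a stated time of 48 h (a lower number here means a stronger inhibitor, a higher number a weaker inhibitor), compound 2 gives the lowest of the three numbers, with 150 nM. The nearest to it is compound 3, which gives 18200 nM; the furthest is compound 1, which gives 48100 nM. Among the measured compounds shown here, the only step between measured compounds that differ in one place is a 2.6-fold lower number from compound 1 to compound 3 (0.42 log units; beyond the scatter), a change on the aromatic carbon of the benzyl part.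

Compound 4 `COc1ccc(CN(C(=O)CO)c2cc(OC)c(OC)c(OC)c2)cc1O` is not yet measured. It differs from compound 2 by hydroxy in place of chloromethyl on a saturated chain carbon bound to a carbonyl carbon. For the measured compounds named here, no measured pair shows this change or any change on the chain attached to the amide carbonyl, so the single measured step does not bear on it; it concerns another part of the molecule and is of modest size. With nothing to anchor the step, the estimate for compound 4 rests on the value of compound 2 alone, widened considerably. Compound 4 is expected at 800 nM in this assay, within 150 nM to 6000 nM, which means an expected step of a 5.3-fold higher number from compound 2 to compound 4 (0.73 log units; beyond the scatter).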

Compound 4, half-maximal inhibitory concentration: 520 nM
The estimate for compound 4 lay 1.5-fold (0.19 log units) above the measured number, and the stated range covers the measured number.
By their numbers in this assay, from the lowest: compound 2; then compound 4; then compound 3; then compound 1.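

In this assay, among the compounds shown here, this is the first measured change on the chain attached to the amide carbonyl: hydroxy in place of chloromethyl on a saturated chain carbon bound to a carbonyl carbon gives a 3.5-fold higher number from compound 2 to compound 4 (0.54 log units; beyond the scatter). The step is modest, so the chlorine-bearing chain is not needed for a number of this order, though the change still lies beyond the scatter and goes towards weaker inhibition. No measurement shown gives a reason for this step.

The compounds shown do not separate the loss of the chlorine from the gain of the hydroxy, as the two arrive together with a shorter chain. From the compounds shown here alone, how an amine, a carboxylic acid or a longer chain ending in hydroxy would read at this place remains open.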